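Methyl for chloro on the triazole aryl group

The source may report more compounds than this note shows. Statements on the series, on what has been measured and on what is new or still open speak of the compounds shown alone.

Measured so far:
compound 1 `C=C1C[C@]23C[C@@]1(O)CC[C@H]2c1ccc(OS(=O)(=O)c2ccc(C)cc2)c(C)c1[C@@H]3Cn1cc(-c2ccc(Cl)cc2)nn1`: > 20000 nM
compound 2 `C=C1C[C@]23C[C@@]1(O)CC[C@H]2c1ccc(OS(=O)(=O)c2ccc(C)cc2)c(C)c1[C@@H]3Cn1cc(-c2ccc(C)cc2)nn1`: > 20000 nM
compound 3 `C=C1C(=O)[C@]23C[C@@]1(O)CC[C@H]2c1ccc(O)c(C)c1[C@@H]3Cn1cc(-c2ccc(Cl)cc2)nn1`: 690 nM

In a functional assay on HL-60 cells (Homo sapiens) for cytotoxicity, read by MTT assay, with a stated time of 4 days (a lower number here means a stronger inhibitor, a higher number a weaker inhibitor), compound 1 `C=C1C[C@]23C[C@@]1(O)CC[C@H]2c1ccc(OS(=O)(=O)c2ccc(C)cc2)c(C)c1[C@@H]3Cn1cc(-c2ccc(Cl)cc2)nn1` reaches only a limit of the assay, > 20000 nM. Compound 2 `C=C1C[C@]23C[C@@]1(O)CC[C@H]2c1ccc(OS(=O)(=O)c2ccc(C)cc2)c(C)c1[C@@H]3Cn1cc(-c2ccc(C)cc2)nn1` likewise gives only a limit there, > 20000 nM. The change between them, (methyl in place of chloro on an aromatic carbon), therefore yields a step whose size cannot be read, a step that the two limits leave unreadable from compound 1 to compound 2, because of the limit of > 20000 nM in this assay, at which 2 of the 3 values shown sit.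

Within the data shown here, compound 3 `C=C1C(=O)[C@]23C[C@@]1(O)CC[C@H]2c1ccc(O)c(C)c1[C@@H]3Cn1cc(-c2ccc(Cl)cc2)nn1` is the one compound with a number in this assay, giving 690 nM. How its core differs from the core of compound 1 is not broken down here.

Compound 4 `C=C1C(=O)[C@]23C[C@@]1(O)CC[C@H]2c1ccc(O)c(C)c1[C@@H]3Cn1cc(-c2ccc(C)cc2)nn1` has not yet been measured. It differs from compound 3 by methyl in place of chloro on an aromatic carbon, the same change as that from compound 1 to compound 2, made at the same place. Since that earlier step is unreadable, the expected step from compound 3 to compound 4 rests only on the smallness of the change in what is counted: compound 4 is expected to sit near compound 3, with a step of about a 1.3-fold higher number from compound 3 to compound 4 (0.12 log units; within the scatter). In this assay compound 4 is expected to give about 900 nM, between 300 nM and 3000 nM.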

Compound 4, half-maximal inhibitory concentration: 830 nM
For compound 4 the middle estimate is 1.1-fold (0.04 log units) above the measured one, and the stated range covers the measured number.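

In this assay, methyl in place of chloro on the triazole aryl group gives a 1.2-fold higher number from compound 3 to compound 4 (0.08 log units; within the scatter), so on this core the 4-chlorophenyl and 4-methylphenyl compounds cannot be told apart. The same change on the core of compound 1 cannot be read, and its step cannot be set against the new one, because both of its ends rest on a limit and not on a number: the limit of > 20000 nM in this assay, at which 2 of the 4 values shown sit. The result thus shows how the change reads on one core only, and it does not show that the change carries from one core to another in this series.

The compounds shown leave open how an amine, a carboxylic acid or a longer chain in the place of the chloro would read in this assay. They also leave open which of the differences between the core of compound 1 and the core of compound 3 goes with the gap between a limit and a number.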